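Naphthalenesulfonamide series: ring amine in place of acyclic amine

The compounds below may be only part of what the source reports. "The series", "measured", "known", "first", "only" and "open" are said of these compounds alone.

Compound 1 `CCCN(C[C@@H](O)CNS(=O)(=O)c1cccc2ccccc12)C(C)(C)C` stands at 1000 nM in an assay on HEK293 cells for inhibition of sodium- and chloride-dependent glycine transporter 1 (Homo sapiens) (on this read-out lower numbers stand for stronger inhibition and higher numbers for weaker inhibition), the only number shown for it besides an entry without a single value. Compound 2 `O=S(=O)(NC[C@H](O)CN1CCCC1C1CCCCC1)c1cccc2ccccc12`, which carries a different ring amine, gives 6310 nM; 6310 nM (2 entries) in this assay. Compound 3 `O=S(=O)(NC[C@H](O)CN1CCCCC1)c1cccc2ccccc12` differs from compound 1 by piperidin-1-yl in place of propyl(tert-butyl)amino on a saturated chain carbon, two bonds along the chain from an oxygen on a saturated carbon. Among the measured compounds shown here, no step between measured compounds covers this change; a step within the usual scatter, or a modest loss, is expected, and the expected step is a 1.6-fold higher number from compound 1 to compound 3 (0.20 log units; within the scatter). For compound 3 the estimate in this assay is 1600 nM, with a range from 400 nM to 6300 nM.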

Compound 3, half-maximal inhibitory concentration: 3160 nM
Compound 3: middle estimate off by 2.0-fold (0.30 log units), on the low side; measured number inside the range.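

With piperidin-1-yl in place of propyl(tert-butyl)amino, this assay gives a modest loss beyond the scatter (a 3.2-fold higher number from compound 1 to compound 3 (0.50 log units; beyond the scatter)). This place on the saturated chain carbon therefore responds to the choice of amine, and this ring does not keep the level of compound 1. Nothing at hand accounts for the size of this step.
Among the compounds shown here, the single step cannot separate the effect of having a ring from that of losing the tert-butyl group. As far as these compounds go, whether diethylamino or morpholin-4-yl at this place comes closer to compound 1 remains open.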